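A chloro swap at the limit of the assay

This account rests on a few compounds, and the source may have more. Where it says the series, first, only, none or still open, it means among the compounds named here.

Measured so far:
Compound 1 `c1ccc(-c2noc(-c3ccncc3)n2)cc1` gives > 1000000 nM as a limit
Compound 2 `COc1ccc(-c2noc(-c3ccccc3)n2)cc1OC1CCCC1` gives > 1000000 nM as a limit
Compound 3 `COc1ccc(-c2noc(-c3ccc(F)cc3)n2)cc1OC1CCCC1` gives > 1000000 nM as a limit

Compound 2 stands only at a limit (> 1000000 nM) in a functional assay on PC-3 cells (Homo sapiens) for antiproliferative activity, read by MTT assay, with a stated time of 24 h (on this read-out higher numbers stand for weaker inhibition and lower numbers for stronger inhibition), and has no number as a starting point. All three compounds share that limit (the limit of > 1000000 nM in this assay, at which 3 of the 3 values shown sit) and none of them gives a number.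

Compound 4 `COc1ccc(-c2noc(-c3ccc(Cl)cc3)n2)cc1OC1CCCC1` is compound 2 with a single change, chloro in place of hydrogen on an aromatic carbon, so that phenyl becomes 4-chlorophenyl. Among the compounds with values here, the one measured step that bears on this puts fluoro in place of hydrogen on an aromatic carbon (a step that the two limits leave unreadable from compound 2 to compound 3). That step has no size to carry over, so no readable step in either direction is expected in this assay for compound 4, which is most likely to report only a limit as well.

Should a number appear, it is expected close to the same level. Compound 4 is estimated at 1000000 nM (expected range 300000 nM to 2000000 nM). That estimate amounts to an expected change (a number no higher from compound 2 to compound 4 (the limit leaves the size open)).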

Compound 4, half-maximal inhibitory concentration: > 1000000 nM
Compound 4: a limit, no number; the forecaster's own chance of this, stated with the estimate: 80%; the middle value sits exactly at the limit.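

In this assay, compound 4 gives only a limit and no number, so no step can be read from compound 2 or compound 3 to compound 4: the limit of > 1000000 nM in this assay, at which 4 of the 4 values shown sit.

The compounds shown leave open whether hydrogen, fluoro or chloro on this aromatic carbon makes any difference to antiproliferative activity.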